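Swapping methyl for fluoro on the sulfonyl aryl ring

A few compounds are considered here, and "the series" means these few. Any claim that something is new, unique, unknown or untested is made for them only; others in the source may bear on it.

Three related compounds were tested in a functional assay on U-87MG ATCC cells (Homo sapiens) for antiproliferative activity, read by MTT assay, with a stated time of 48 h; a lower number here means a stronger inhibitor, a higher number a weaker inhibitor. Compound 1 `COc1ncc(-c2ccc3nc(NC(C)=O)nn3c2)cc1NS(=O)(=O)c1ccc(F)cc1` gives 1820 nM, and compound 2 `COc1ncc(-c2ccc3nc(NC(C)=O)nn3c2)cc1NS(=O)(=O)c1ccc(C)cc1` gives 1600 nM. The two differ only by fluoro in place of methyl on an aromatic carbon, and this change produced a 1.1-fold higher number from compound 2 to compound 1 (0.06 log units; within the scatter). Compound 3 `COc1ncc(-c2ccn3nc(NC(C)=O)nc3c2)cc1NS(=O)(=O)c1ccc(C)cc1` gives 2030 nM; it has the same atoms as compound 2 joined differently, and the difference between the two cores is not broken down here. Compound 4 `COc1ncc(-c2ccn3nc(NC(C)=O)nc3c2)cc1NS(=O)(=O)c1ccc(F)cc1` has not been measured. It differs from compound 3 by fluoro in place of methyl on an aromatic carbon, the same kind of change as that between compound 2 and compound 1. The step from compound 3 to compound 4 is expected to be a 1.1-fold higher number from compound 3 to compound 4 (0.03 log units; within the scatter), because the same change gave a 1.1-fold higher number from compound 2 to compound 1 (0.06 log units; within the scatter). Compound 4 is therefore estimated at 2200 nM, with a likely range from 1300 nM to 3800 nM.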

Compound 4, half-maximal inhibitory concentration: 2410 nM
The estimate for compound 4 lay 1.1-fold (0.04 log units) below the measured number; the range from low to high includes it.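

In this assay, fluoro in place of methyl gives a 1.2-fold higher number from compound 3 to compound 4 (0.07 log units; within the scatter) on the second core. Set beside the first core, the change looks much the same on both: the same change on two cores in this assay, a 1.1-fold higher number (0.06 log units; within the scatter) from compound 2 to compound 1 and a 1.2-fold higher number (0.07 log units; within the scatter) from compound 3 to compound 4, 1.0-fold (0.02 log units) apart, within the scatter of two such steps. Since neither step lies beyond the scatter, this shows only that swapping methyl for fluoro left the number about where it was on these two cores, not that the swap would behave this way on any other core or that a change with a larger effect would carry over as well.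

The compounds shown hold only methyl and fluoro at this place on the ring. On these data alone, whether an amine, a carboxylic acid or a longer chain there would shift the number beyond the scatter, and whether that shift would match on both cores, stays open.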